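The source may report more compounds than this note shows. Statements on the series, on what has been measured and on what is new or still open speak of the compounds shown alone.

Working notes on the series.

For the measured compounds named here, compound 2 `Cn1nccc1C(=O)Nc1ccc(-c2ccccc2Cl)c(N)n1` stands highest of the two numbers measured so far in an assay on HEK293 cells for inhibition of sodium channel protein type 10 subunit alpha (Homo sapiens), read by fluorescence (on this read-out higher numbers stand for weaker inhibition and lower numbers for stronger inhibition), where compound 2 gives 4900 nM. The nearest point is compound 1 `Cn1nccc1C(=O)Nc1ccc(-c2cc(Cl)ccc2Cl)c(N)n1`, which in this assay gives 920 nM. Going by the values given here, the only measured step, a 5.3-fold higher number from compound 1 to compound 2 (0.73 log units; beyond the scatter), is hydrogen in place of chloro on an aromatic carbon of the same six-membered ring.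

Compound 3 `Cn1nccc1C(=O)Nc1ccc(-c2ccc(F)cc2Cl)c(N)n1` differs from compound 2 by fluoro in place of hydrogen on an aromatic carbon. This is the reverse sense of the measured step, a single atom entering at an aromatic carbon, but fluoro rather than chloro and at a different aromatic carbon of that ring, meta to a chloro group and para to a large group. One step cannot show whether the effect carries over; a smaller move in the lowering direction is the working expectation, as a 2.0-fold lower number from compound 2 to compound 3 (0.29 log units; within the scatter), because compound 1 with its second chloro gives 920 nM. Compound 3 is therefore expected near 2500 nM, within 900 nM to 6500 nM.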

Compound 3, half-maximal inhibitory concentration: 31000 nM
Compound 3: the middle estimate sits 12-fold (1.09 log units) below what was measured; measured number outside the range, above it.
By their numbers in this assay, from the lowest: compound 1; then compound 2; then compound 3.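

In this assay, adding an atom to the 2-chlorophenyl ring does not of itself lower the number: fluoro para to a large group gives a 6.3-fold higher number from compound 2 to compound 3 (0.80 log units; beyond the scatter), whereas the second chloro of compound 1 goes with the lower number, as a 5.3-fold higher number from compound 1 to compound 2 (0.73 log units; beyond the scatter) shows. The exchange of 2,5-dichlorophenyl for 2-chloro-4-fluorophenyl gives a 34-fold higher number from compound 1 to compound 3 (1.53 log units; beyond the scatter), the widest gap among these three compounds, so changes on this ring alone, with the rest of the structure held constant, span this whole range. Nothing available explains why the two additions part in direction.

Still open, as far as these compounds go, is whether the rise follows the fluoro atom or the carbon it occupies, since the two changes differ in both atom and place. A chloro, methoxy or amine at that same carbon, para to the large group, would help separate these two readings.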